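Replacing the thiophene arm with a carbamate chain

The source may report more compounds than this note shows. Statements on the series, on what has been measured and on what is new or still open speak of the compounds shown alone.

Compound 3 `CCCSc1nc(Cl)c2c(n1)N(Cc1cccs1)C(C(=O)N1CCN(C)CC1)N2` gives 5020 nM in a functional assay on PC-3 cells (Homo sapiens) for antiproliferative activity, read by MTT assay, with a stated time of 72 h (on this read-out lower numbers stand for stronger inhibition and higher numbers for weaker inhibition), the lowest of the three numbers recorded. Compound 1 `CCCSc1nc(Cl)c2c(n1)N(Cc1ccccc1)C(C(=O)N1CCN(Cc3ccccc3)CC1)N2` gives 57300 nM and compound 2 `CCCSc1nc(Cl)c2c(n1)N(Cc1ccccc1)C(C(=O)N1CCN(C(=O)OC(C)(C)C)CC1)N2` gives 47100 nM; between them lies a 1.2-fold lower number from compound 1 to compound 2 (0.09 log units; within the scatter). Compound 4 `CCCSc1nc(Cl)c2c(n1)N(CCNC(=O)OC(C)(C)C)C(C(=O)N1CCN(C)CC1)N2` differs from compound 3 by ((tert-butoxycarbonyl)amino)methyl in place of thiophen-2-yl on a saturated chain carbon bound to a nitrogen on an aromatic ring in a ring. Within the data shown here, no measured step touches this place: the single step recorded swaps tert-butoxycarbonyl for benzyl on an amine nitrogen in a ring and stayed within the scatter, so it speaks only loosely to the arrival of the same carbamate on the chain carbon here. The step from compound 3 to compound 4 is therefore expected to be modest, a 2.4-fold higher number from compound 3 to compound 4 (0.38 log units; beyond the scatter), with no firm direction. Compound 4 is estimated at 12000 nM, in the range 3000 nM to 50000 nM.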

Compound 4, half-maximal inhibitory concentration: > 64000 nM
Compound 4: only a limit was reported (the forecaster's own chance of this, stated with the estimate: 10%); middle value at least 5.3-fold (0.72 log units) away from the limit.
By their numbers in this assay, from the lowest: compound 3; then compounds 2 and 1 (each within the scatter of the next). At a limit, above all of these: compound 4.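

Among these compounds, exchanging (thiophen-2-yl)methyl for 2-((tert-butoxycarbonyl)amino)ethyl gives an at least 12-fold higher number from compound 3 to compound 4 (1.10 log units; beyond the scatter), so the group on this saturated chain carbon matters in a way the one earlier step, made on an amine nitrogen in a ring and within the scatter, did not show. In this assay compound 4 gives only a limit, not a number: the limit of > 64000 nM in this assay, at which 1 of the 4 values shown sits.

The compounds shown leave open whether the loss of the thiophene ring or the arrival of the carbamate carries this step. Going by these compounds, how a free amine on the same ethyl chain, or a plain alkyl chain, would read also stays open.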